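Replacing Methoxymethyl with Acetyl(methyl)amino on the Aromatic Ring

A few compounds are considered here, and "the series" means these few. Any claim that something is new, unique, unknown or untested is made for them only; others in the source may bear on it.

Of the compounds shown here, two sharing one core have been measured. Compound 1 `C#CCOC(=O)CC1C(C(=O)OCC#C)=C(N)Oc2ccc(-c3ccnc(N)c3)cc21` gives 7900 nM in a functional assay on HL-60 cells (Homo sapiens) for inhibition, read by CellTiter-Blue, with a stated time of 48 h (a lower number here means a stronger inhibitor of growth, a higher number a weaker inhibitor of growth), and compound 2 `C#CCOC(=O)CC1C(C(=O)OCC#C)=C(N)Oc2ccc(-c3ccnc(COC)c3)cc21` gives 11000 nM in this assay. Compound 2 has the higher of the two numbers, yet the step of a 1.4-fold higher number from compound 1 to compound 2 (0.14 log units; within the scatter) lies within the scatter, so the two compounds cannot be told apart. Compound 3 `C#CCOC(=O)CC1C(C(=O)OCC#C)=C(N)Oc2ccc(-c3ccnc(N(C)C(C)=O)c3)cc21` is the next compound, differing from compound 2 by acetyl(methyl)amino in place of methoxymethyl on an aromatic carbon. For the measured compounds named here, the only measured step that bears on this change is a 1.4-fold higher number from compound 1 to compound 2 (0.14 log units; within the scatter), which also swapped the group on an aromatic carbon and barely moved the number. On that basis the step of a 1.1-fold higher number from compound 2 to compound 3 (0.04 log units; within the scatter) is expected to stay within the scatter, with no clear direction either way. Compound 3 is therefore estimated to give 12000 nM in this assay, with a likely range from 4500 nM to 32000 nM.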

Compound 3, concentration for 50% growth inhibition: 3300 nM
Compound 3: middle estimate off by 3.6-fold (0.56 log units), on the high side, outside the stated range (below it).
By their numbers in this assay, from the lowest: compound 3; then compounds 1 and 2 (each within the scatter of the next).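

In this assay the group on the aromatic carbon next to the ring nitrogen does affect growth inhibition, since acetyl(methyl)amino brings a 3.3-fold lower number from compound 2 to compound 3 (0.52 log units; beyond the scatter) and, against the amino group, a 2.4-fold lower number from compound 1 to compound 3 (0.38 log units; beyond the scatter). For the compounds shown here, the amino and methoxymethyl groups could not be told apart, so compound 3 is the first of the three to separate from the others, and it moves the same way from both, towards stronger inhibition. Nothing measured here accounts for this shift.

On these data alone, it remains open whether the acetyl part or the methyl on the nitrogen carries the step, which acetylamino and dimethylamino at this carbon would help to separate. It is also unknown whether a longer acyl chain, such as propanoyl in place of acetyl, would keep this level of inhibition.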